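Expected antiproliferative activity of compound 4 on the shared core

The source may hold more compounds than are shown below. What is called first, only, known or untested is meant among the compounds shown, and "the series" means these compounds.

Measured compounds, read in a functional assay on KB cells (Homo sapiens) for antiproliferative activity, read by MTT assay, with a stated time of 48 h; on this read-out higher numbers stand for weaker inhibition and lower numbers for stronger inhibition:
Compound 1 `CCOC(=O)N1CCC(N(Cc2cc(Cl)ccc2O)C(=O)N(C)C)CC1` gives 25700 nM.
Compound 2 `CCOC(=O)N1CCC(N(Cc2ccc(O)cc2)C(=O)N(C)C)CC1` gives 48600 nM.
Compound 3 `CCOC(=O)N1CCC(N(Cc2ccc([N+](=O)[O-])cc2)C(=O)N(C)C)CC1` gives 16400 nM.

Among the measured compounds shown here, compound 3 carries the lowest of the three numbers; its gap to compound 1 is within the scatter, and only the step of a 3.0-fold lower number from compound 2 to compound 3 (0.47 log units; beyond the scatter) stands beyond it. Compound 4 `CCOC(=O)N1CCC(N(Cc2cc(Br)ccc2O)C(=O)N(C)C)CC1` is the next analogue, with 5-bromo-2-hydroxyphenyl in place of 4-nitrophenyl on a saturated chain carbon bound to an amide-type nitrogen. For the measured compounds named here, no measured step reproduces this change exactly. The closest is the reverse of a 1.6-fold lower number from compound 1 to compound 3 (0.20 log units; within the scatter), where the chloro analogue and the nitro analogue sit within the scatter of each other. Going by the values given here, compound 4 differs from compound 1 only in bromine replacing chlorine on the aromatic ring, a change for which no measured pair exists here. On that basis compound 4 is expected to come close to compound 1 in this assay, which means a step of a 1.6-fold higher number from compound 3 to compound 4 (0.20 log units; within the scatter) that is not expected to reach beyond the scatter. Compound 4 is therefore estimated at 26000 nM, with a range from 12000 nM to 55000 nM.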

Compound 4, half-maximal inhibitory concentration: 24600 nM
Compound 4: the middle estimate sits 1.1-fold (0.02 log units) above what was measured, and the stated range covers the measured number.
By their numbers in this assay, from the lowest: compounds 3, 4, 1 and 2 (each within the scatter of the next, the first and the last beyond it).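

In this assay bromo in place of chloro on an aromatic carbon gives a step within the scatter (a 1.0-fold lower number from compound 1 to compound 4 (0.02 log units; within the scatter)), so the only halogen pair shown does not separate the two analogues. At the saturated chain carbon bound to an amide-type nitrogen, 5-bromo-2-hydroxyphenyl also stays within the scatter of 4-nitrophenyl (a 1.5-fold higher number from compound 3 to compound 4 (0.18 log units; within the scatter)) and of 4-hydroxyphenyl (a 2.0-fold lower number from compound 2 to compound 4 (0.30 log units; within the scatter)). Compound 4 therefore cannot be separated from any of the three earlier compounds, although compound 2 and compound 3 remain separated from each other. No evidence accompanying these results bears on them. On these data alone, whether an amine, a carboxylic acid or a longer chain in this place would move the number beyond the scatter remains open. Also open, as far as these compounds go, is whether changes elsewhere on the shared core would have a larger effect than those in this aryl group.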